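Nitro removal on two related beta-lactam ester cores

The source may report more compounds than this note shows. Statements on the series, on what has been measured and on what is new or still open speak of the compounds shown alone.

Of the compounds shown here, three have been measured in a functional assay on OE19 cells (Homo sapiens) for cytotoxicity, read by MTT assay, with a stated time of 48 h; on this read-out lower numbers stand for stronger inhibition and higher numbers for weaker inhibition. Compound 1, with the structure `CC1(C)[C@H](C(=O)OC(c2ccccc2)c2ccccc2)N2C(=O)/C(=C/C(=O)c3ccc([N+](=O)[O-])cc3)[C@H]2[S+]1[O-]`, gives 92400 nM. Compound 2, with the structure `CC1(C)S[C@@H]2/C(=C\C(=O)c3ccc([N+](=O)[O-])cc3)C(=O)N2[C@H]1C(=O)OC(c1ccccc1)c1ccccc1`, gives 44100 nM. Compound 3, with the structure `CC1(C)S[C@@H]2/C(=C\C(=O)c3ccccc3)C(=O)N2[C@H]1C(=O)OC(c1ccccc1)c1ccccc1`, gives 12800 nM and stands lowest of the three. The difference between the cores of compound 1 and compound 2 is not broken down here.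

The change from compound 2 to compound 3 is hydrogen in place of nitro on an aromatic carbon, and it produced a 3.4-fold lower number from compound 2 to compound 3 (0.54 log units; beyond the scatter). The unmeasured compound 4, with the structure `CC1(C)[C@H](C(=O)OC(c2ccccc2)c2ccccc2)N2C(=O)/C(=C/C(=O)c3ccccc3)[C@H]2[S+]1[O-]`, carries the same change on the core of compound 1: hydrogen in place of nitro on an aromatic carbon. The place of the change is the same in both pairs, so it is the same change applied to a different core. Taking the measured step from compound 2 to compound 3 as the guide, the step from compound 1 to compound 4 is expected to be a 3.3-fold lower number from compound 1 to compound 4 (0.52 log units; beyond the scatter). On that basis compound 4 is estimated to give 28000 nM, within a range from 12000 nM to 65000 nM, in this assay.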

Compound 4, half-maximal inhibitory concentration: 23700 nM
For compound 4 the middle estimate is 1.2-fold (0.07 log units) above the measured one, and the stated range covers the measured number.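

In this assay, hydrogen in place of nitro on an aromatic carbon of the core of compound 1 gave a 3.9-fold lower number from compound 1 to compound 4 (0.59 log units; beyond the scatter). Set beside the earlier step on the other core, the change carries over with its size preserved: the same change on two cores in this assay, a 3.4-fold lower number (0.54 log units; beyond the scatter) from compound 2 to compound 3 and a 3.9-fold lower number (0.59 log units; beyond the scatter) from compound 1 to compound 4, 1.1-fold (0.05 log units) apart, within the scatter of two such steps. Among these compounds, this rests on only two matched pairs, so it shows agreement for 4-nitrophenyl to phenyl on these two cores in this one cell read-out, but it does not show that the step would hold on any further core or with any other group, nor does it explain why the numbers fall.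

The compounds shown carry only nitro or hydrogen at this place on the ring, so it remains open how an amine, a methoxy group or a halogen there would compare. The diphenylmethyl ester is also common to all of them, which leaves open whether the same step would appear with a carboxylic acid in its place.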